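The source may report more compounds than this note shows. Statements on the series, on what has been measured and on what is new or still open speak of the compounds shown alone.

Measured so far:
Compound 1 `CN1C(=O)C=C(Cl)C1(O)c1ccccc1`: 2500 nM
Compound 2 `O=C1C=C(Cl)C(O)(c2ccc(Cl)cc2)N1C1CCCC1`: 2500 nM

In an assay on cell membranes for displacement of a labelled ligand from Cholecystokinin receptor type A (Rattus norvegicus), read by CCK-8 assay, with a stated time of 2 h (on this read-out higher numbers stand for weaker inhibition and lower numbers for stronger inhibition), compound 1 gives 2500 nM, and compound 2 gives 2500 nM. The two values are the same at the digits recorded, so neither compound can be called stronger than the other. Within the data shown here, compound 2 differs from compound 1 in two places at once, so the numbers say only that both changes together leave the read-out where it was.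

Compound 3 `CC(C)(C)N1C(=O)C=C(Cl)C1(O)c1ccccc1` is the next compound; it carries a (tert-butyl in place of methyl on an amide-type nitrogen in a ring). Among the measured compounds shown here, no measured pair shows this change on its own, so its effect has to be estimated. For the measured compounds named here, the only guide is that compound 2, which carries a larger group than methyl on the amide-type nitrogen in the ring, is level with compound 1 and gives for compound 2 2500 nM. The step from compound 1 to compound 3 is therefore expected to be small, no change at the digits printed from compound 1 to compound 3 (within the scatter), with no direction favoured beyond the usual scatter. Compound 3 is expected to give about 2500 nM in this assay, with a likely range from 800 nM to 8000 nM.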

Compound 3, half-maximal inhibitory concentration: 120 nM
For compound 3 the middle estimate is 21-fold (1.32 log units) above the measured one; the measured number lies below the stated range.
By their numbers in this assay, from the lowest: compound 3; then compounds 1 and 2 (each within the scatter of the next).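

In this assay tert-butyl in place of methyl on the amide-type nitrogen in the ring gives a 21-fold lower number from compound 1 to compound 3 (1.32 log units; beyond the scatter) with nothing else in the core of compound 1 altered. Among these compounds, this is the first change at this position that can be read on its own, and it shows that the group on this nitrogen can by itself move the number well beyond the scatter, which the earlier pair, differing in two places at once, could not show. No measurement shown here explains why this swap has so large an effect.

Going by these compounds, it remains open whether the gain follows the number of carbons or the branching of the group, which a straight butyl chain or an isopropyl group on the same nitrogen could help separate. On these data alone, it is also open how this position would respond to a group carrying an amine or a carboxylic acid.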